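The source may report more compounds than this note shows. Statements on the series, on what has been measured and on what is new or still open speak of the compounds shown alone.

In a functional assay on CLL cells (Homo sapiens) for cytotoxicity, read by MTT assay, with a stated time of 48 h (a higher number here means that more compound is needed for the effect, a lower number that less compound is needed), compound 3 `C=C(CC)C(=O)c1ccc(OCC(=O)NCO[N+](=O)[O-])c(Cl)c1Cl` gives 4100 nM, level within the scatter with compound 1 `C=C(CC)C(=O)c1ccc(OCC(=O)Nc2ccc(C(=O)O)cc2)c(Cl)c1Cl` at 5000 nM. The only other result is a limit: compound 2 `C=C(CC)C(=O)c1ccc(OCC(=O)Nc2ccc(S(=O)(=O)O)cc2)c(Cl)c1Cl` gives > 25000 nM. Compound 4 `C=C(CC)C(=O)c1ccc(OCC(=O)Nc2ccc(O)cc2)c(Cl)c1Cl` carries 4-hydroxyphenyl in place of (nitrooxy)methyl on an amide-type nitrogen. For the measured compounds named here, two measured steps bear on this change. Placing (nitrooxy)methyl where 4-carboxyphenyl stood gave a 1.2-fold lower number from compound 1 to compound 3 (0.09 log units; within the scatter), so that exchange on the same nitrogen left the number unmoved. Sulfo in place of carboxy on the aromatic carbon gave an at least 5.0-fold higher number from compound 1 to compound 2 (0.69 log units; beyond the scatter), so a change on that ring can raise the number. In this assay the expected change is a 1.1-fold higher number from compound 3 to compound 4 (0.04 log units; within the scatter), none beyond the scatter. The expected value for compound 4 is 4500 nM, with an estimated range of 1800 nM to 12000 nM.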

Compound 4, half-maximal effective concentration: 6400 nM
Compound 4: middle estimate off by 1.4-fold (0.15 log units), on the low side, and the stated range covers the measured number.
By their numbers in this assay, from the lowest: compounds 3, 1 and 4 (each within the scatter of the next). At a limit, above all of these: compound 2.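

In this assay hydroxy on the aromatic carbon stands level with carboxy (a 1.3-fold higher number from compound 1 to compound 4 (0.11 log units; within the scatter)), and 4-hydroxyphenyl on the amide-type nitrogen stands level with (nitrooxy)methyl (a 1.6-fold higher number from compound 3 to compound 4 (0.19 log units; within the scatter)). Among the groups at this place, only sulfo separates from the rest, and hydroxy in its place gives the step beyond the scatter (an at least 3.9-fold lower number from compound 2 to compound 4 (0.59 log units; beyond the scatter)). The value of compound 2 is a limit, not a number: the limit of > 25000 nM in this assay, at which 1 of the 4 values shown sits. From the compounds shown here alone, whether an amine or a methoxy group on that aromatic carbon, or a longer chain carrying the nitrooxy group on the nitrogen, would stay level with these compounds remains open.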